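The compounds below may be only part of what the source reports. "The series", "measured", "known", "first", "only" and "open" are said of these compounds alone.

Compound 1, `FC(F)(F)c1cccc(-c2cn3ccnc3c(-c3ccc4ncn(C5CCCCC5)c4c3)n2)c1`: 17.6%
Compound 2, `CCc1ccc(-c2cn3ccnc3c(-c3ccc4ncn(Cc5ccccc5)c4c3)n2)cc1`: 61.2%

Both compounds were tested in a functional assay on HCT-116 cells (Homo sapiens) for inhibition, read by sulforhodamine B assay, with a stated time of 48 h, tested at 10 uM; on this read-out lower numbers stand for less inhibition and higher numbers for more inhibition at the one concentration tested (going by the name of the read-out). Compound 2 gives 61.2%, the higher of the two numbers. Compound 1 gives 17.6%, and the gap between the two lies beyond the usual scatter of this measurement. Within the data shown here, compound 1 and compound 2 differ from each other in more than one place, so no single structural step links them, and all that can be said is what their two values show.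

The new compound, compound 3, `c1ccc(Cn2cnc3ccc(-c4nc(-c5cccc6ccccc56)cn5ccnc45)cc32)cc1`, is related to compound 2 by one change: naphthalen-1-yl in place of 4-ethylphenyl on an aromatic carbon. Among the measured compounds shown here, no measured pair in this set shows a change of this kind, so its size cannot be read from the data. With only a single reference point, the expectation is a modest downward move, not clearly beyond the scatter: the step is expected to be a number 11.2 percentage points lower from compound 2 to compound 3 (beyond the scatter). On that basis compound 3 is estimated at 50%, with a range from 20% to 80%.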

Compound 3, a percentage reported as inhibition, at one concentration (the size of the read-out at that concentration, not a potency): 32.9%
The estimate for compound 3 lay 17.1 percentage points above the measured number; the range from low to high includes it.
By their numbers in this assay, from the lowest: compound 1; then compound 3; then compound 2.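

Among these compounds, this is the first step in the set that can be read at a single place. In this assay, putting naphthalen-1-yl in place of 4-ethylphenyl, on the aromatic carbon next to the ring nitrogen, gives a number 28.3 percentage points lower from compound 2 to compound 3 (beyond the scatter), so the number at this position depends on which group sits there. The swap adds a second six-membered aromatic ring of carbon only and removes the ethyl chain, while the counts of hydrogen-bond donors and acceptors stay the same, so the shift in the number comes without any change in those counts. Nothing measured here accounts for the size or direction of this step.

A single step cannot separate the effect of the second ring from that of losing the ethyl chain, and a phenyl ring carrying a methoxy group, an amine or a longer propyl chain at this position would help to tell the two apart. Also open, from the compounds shown here alone, is whether this swap would give a similar step on a compound with cyclohexyl in place of benzyl, as the core of compound 1 carries.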